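A Bromine Swap on the Hydrazone Aryl Ring

The source may report more compounds than this note shows. Statements on the series, on what has been measured and on what is new or still open speak of the compounds shown alone.

Of the compounds shown here, two built on a shared core have been tested in a functional assay on the whole organism for inhibition, with Rattus norvegicus as the target; on this read-out higher numbers stand for an effect only at larger amounts of compound and lower numbers for an effect already at smaller amounts. Compound 1, `CC1CC/C(=N\Nc2cccc(C(=O)O)c2)c2nccc(=O)n21`, returned only a limit of the assay in this assay, > 100 umol/kg. Compound 2, `CC1CC/C(=N\Nc2cccc(Cl)c2)c2ncc(C(=O)O)c(=O)n21`, also returned only a limit in this assay, > 100 umol/kg. For the measured compounds named here, compound 2 thus stands where every measured value so far stands, because of the limit of > 100 umol/kg in this assay, at which 2 of the 2 values shown sit; no difference between the two compounds can be read from this. Compound 3, `CC1CC/C(=N\Nc2ccc(Br)cc2)c2ncc(C(=O)O)c(=O)n21`, is the next candidate. It differs from compound 2 in one place: 4-bromophenyl in place of 3-chlorophenyl on an amine nitrogen. The 3-chlorophenyl leaves and a 4-bromophenyl enters, on an amine nitrogen whose other neighbour is a double-bonded nitrogen. Going by the values given here, with no measured step to lean on, the expected change from compound 2 to compound 3 is a step that the limit leaves unreadable from compound 2 to compound 3, a step within the usual scatter. Compound 3 is therefore estimated to give 150 umol/kg in this assay, within a range from 50 umol/kg to 500 umol/kg, most likely once more only a limit.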

Compound 3, dose for 50% inhibition: > 1000 umol/kg
Compound 3 was reported as a limit; the forecaster's own chance of this, stated with the estimate: 75%; middle value at least 6.6-fold (0.82 log units) away from the limit.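

In this assay, for the compounds shown here, compound 2 and compound 3 each gave only a limit and not a number, so no step between them can be read. The compounds shown leave open whether 4-bromophenyl in place of 3-chlorophenyl changes the dose needed at all, and what that dose would be.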